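Methoxy in Place of Cyano: Expected Tolerance in MT4 Cells

The compounds below may be only part of what the source reports. "The series", "measured", "known", "first", "only" and "open" are said of these compounds alone.

Three thiocarbamates sharing one core have been examined in an ADME assay on MT4 cells (Homo sapiens) for cytotoxicity, read by MTT assay; a lower number here means that less compound is tolerated, a higher number that more compound is tolerated. Compound 1 `Cc1ccccc1NC(=S)OCCc1ccccn1` carries a methyl group on the aniline ring, and in this assay compound 1 reaches only the limit of the measurement, > 100000 nM. Compound 2 `Cc1cccc(NC(=S)OCCc2ccccn2)c1` carries the methyl group at a different position, and compound 2 likewise gives no number but the limit > 100000 nM. Within the data shown here, compound 3 `N#Cc1ccc(NC(=S)OCCc2ccccn2)cc1`, bearing a cyano group, is the one member of the set for which a figure is recorded: in this assay compound 3 gives 45000 nM. Among the measured compounds shown here, compound 3 therefore stands alone as the only measured number, while the other two entries sit at the limit of > 100000 nM in this assay, at which 2 of the 3 values shown sit.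

The next compound, compound 4 `COc1ccc(NC(=S)OCCc2ccccn2)cc1`, differs from compound 3 in a single place: methoxy in place of cyano on an aromatic carbon. For the measured compounds named here, no measured pair in the set reproduces this change, so its size can only be expected. Since the two compounds without a cyano group, compound 1 and compound 2, sit at the limit, the step from compound 3 to compound 4 is expected to move upward, toward more tolerated compound, by a 2.0-fold higher number from compound 3 to compound 4 (0.30 log units; within the scatter). In this assay compound 4 is accordingly expected to give about 90000 nM, within a range from 40000 nM to 200000 nM, with a fair chance that only a limit is reported.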

Compound 4, half-maximal cytotoxic concentration: 48000 nM
Compound 4: the middle estimate sits 1.9-fold (0.27 log units) above what was measured, within the range that was stated.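

At this place on the aromatic ring, para to a large group, the exchange of cyano for methoxy gives in this assay a 1.1-fold higher number from compound 3 to compound 4 (0.03 log units; within the scatter). Among these compounds, this is the first pair in the set that differs in one place, so the position now has a direct reading: with this change, the tolerated concentration of the two compounds cannot be told apart. Compound 3 and compound 4 both give a number, which shows that a number in this assay does not require the cyano group at this place, and neither compound shares the reading of the remaining entries, which is a limit and not a number: the limit of > 100000 nM in this assay, at which 2 of the 4 values shown sit.

The compounds shown leave open whether another group at this place, such as an amine, a carboxylic acid or a longer chain, would stay level with these two values or part from them. They also leave open how the same exchange of cyano for methoxy would read at another place on the aromatic ring, for this single pair speaks only for the one place it covers.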